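Cyano gives way to isopropyl on the shared core

The source may hold more compounds than are shown below. What is called first, only, known or untested is meant among the compounds shown, and "the series" means these compounds.

Measured in a toxicity assay on CCRF-CEM cells (Homo sapiens) for cytotoxicity; on this read-out lower numbers stand for higher toxicity in this test and higher numbers for lower toxicity in this test:
Compound 1 `CC(=O)N(C)c1cccc2c1nc(-c1c(F)cccc1F)n2Cc1c(F)cccc1F`: > 100 uM (a limit of the assay)
Compound 2 `N#Cc1cccc2c1nc(-c1c(F)cccc1F)n2Cc1c(F)cccc1F`: 26.7 uM

Within the data shown here, compound 2, at 26.7 uM, holds the only true number so far. Compound 1 gives only a limit, > 100 uM.

Compound 3 `CC(C)c1cccc2c1nc(-c1c(F)cccc1F)n2Cc1c(F)cccc1F` carries isopropyl in place of cyano on an aromatic carbon. Among the measured compounds shown here, one measured step bears on this change, since it concerns the same aromatic carbon: an at least 3.7-fold lower number from compound 1 to compound 2 (0.57 log units; beyond the scatter). There, the arrival of cyano went with the lower number, so its departure is expected to move the number up, though isopropyl itself has not been tested. A single step bounded by a limit is a thin guide, so only a modest move is expected in this assay. The expected step, upward if any, is a 1.7-fold higher number from compound 2 to compound 3 (0.23 log units; within the scatter). Compound 3 is estimated at 45 uM, with an expected range from 15 uM to 100 uM.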

Compound 3, half-maximal toxic concentration: 27 uM
Compound 3: the middle estimate sits 1.7-fold (0.22 log units) above what was measured, and the stated range covers the measured number.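

In this assay, isopropyl in place of cyano on this aromatic carbon gives a 1.0-fold higher number from compound 2 to compound 3 (0.00 log units; within the scatter), so two groups that share neither a heavy-atom count nor a hydrogen-bond acceptor count leave the read-out unmoved. The lower number seen with cyano is therefore not unique to cyano, and isopropyl shows the same separation from acetyl(methyl)amino, with an at least 3.7-fold lower number from compound 1 to compound 3 (0.56 log units; beyond the scatter). Compound 1 stands at a limit, so this separation is bounded on one side only: the limit of > 100 uM in this assay, at which 1 of the 3 values shown sits.

The compounds shown leave open whether the higher number belongs to acetyl(methyl)amino alone or would also come with a simple amine, a carboxylic acid or a longer alkyl chain on this carbon. They also leave open how the read-out responds to changes elsewhere on the shared core.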